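Swapping the Aryl Group in a Spirocyclic Amine Series

The source may hold more compounds than are shown below. What is called first, only, known or untested is meant among the compounds shown, and "the series" means these compounds.

Compound 1 `Cn1ncc2cc(-c3cnc4[nH]ncc4c3N3CCC4(CCNC4=O)CC3)ccc21`: 214 nM
Compound 2 `Cn1ncc2cc(-c3cnc4sccc4c3N3CCC4(CCNC4=O)CC3)ccc21`: "not determined" (no result reported)
Compound 3 `O=C1NCCC12CCN(c1c(-c3ccc4scnc4c3)cnc3[nH]ccc13)CC2`: 14 nM

In an assay on cells for binding affinity to Cyclin-C/Cyclin-dependent kinase 19 (Homo sapiens), read by LanthaScreen (a higher number here means a weaker inhibitor, a lower number a stronger inhibitor), compound 3 gives 14 nM, the lower of the two numbers recorded. Compound 1 gives 214 nM, and the gap to compound 3 lies well beyond the usual scatter, though the two compounds differ in more than one place. Compound 2 gives "not determined" (no result reported) in this assay.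

Compound 4 `Cn1cnc2cc(-c3cnc4[nH]ccc4c3N3CCC4(CCNC4=O)CC3)ccc21` carries 1-methyl-1H-benzimidazol-5-yl in place of 1,3-benzothiazol-5-yl on an aromatic carbon. Going by the values given here, no measured pair isolates this single change, so the expectation rests only on the wide spread between compound 3 and compound 1. Compound 4 is expected to give 30 nM (range 8 nM to 120 nM), an estimated step of a 2.1-fold higher number from compound 3 to compound 4 (0.33 log units; beyond the scatter), a modest move toward a weaker inhibitor, not clearly beyond the scatter.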

Compound 4, half-maximal inhibitory concentration: 50 nM
Estimate against measurement, compound 4: 1.7-fold (0.22 log units) below, and the stated range covers the measured number.
By their numbers in this assay, from the lowest: compound 3; then compound 4; then compound 1.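

Going by these compounds alone, replacing 1,3-benzothiazol-5-yl with 1-methyl-1H-benzimidazol-5-yl gives a 3.6-fold higher number from compound 3 to compound 4 (0.55 log units; beyond the scatter) in this assay, the first comparison here that isolates a change in one place. Both groups join a five-membered aromatic ring to a six-membered aromatic ring of carbon only, so this position responds to the identity of the fused group even when those ring types stay the same. No measurement here accounts for the step. Still open, going by these compounds, is how this position would respond to a benzimidazol-5-yl without the methyl, or to a phenyl ring carrying an amine or a carboxylic acid.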